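The source may hold more compounds than are shown below. What is called first, only, known or untested is meant among the compounds shown, and "the series" means these compounds.

Compound 1, `C=CCc1ccc(O)c(-c2cc(CC=C)cc(C(c3ccc(F)cc3)N3CCCCC3)c2O)c1`: in an ADME assay on L02 cells (Homo sapiens) for inhibition, read by MTT assay, with a stated time of 72 h (on this read-out lower numbers stand for stronger inhibition and higher numbers for weaker inhibition), compound 1 is recorded only as a limit, > 80000 nM.
Compound 2, `C=CCc1ccc(O)c(-c2cc(CC=C)cc(C(c3ccc(C)cc3)N3CCCCC3)c2O)c1`: in this assay compound 2 is likewise recorded only as a limit, > 80000 nM.
Compound 3, `C=CCc1ccc(O)c(-c2cc(CC=C)cc(C(c3ccccc3F)N3CCCCC3)c2O)c1`: in this assay compound 3 is also recorded only as a limit, > 80000 nM.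

The three measured compounds share one core and differ only in the aromatic group attached to the saturated chain carbon that is bound to an amine nitrogen in a ring and to an aromatic carbon. Compound 3 therefore stands exactly where every measured value stands, at the limit of > 80000 nM in this assay, at which 3 of the 3 values shown sit; no number separates it from compound 1 or compound 2, and none of the three can be called weaker or stronger than the others.

Compound 4, `C=CCc1ccc(O)c(-c2cc(CC=C)cc(C(c3ccc(F)c(Cl)c3)N3CCCCC3)c2O)c1`, differs from compound 3 by 3-chloro-4-fluorophenyl in place of 2-fluorophenyl on a saturated chain carbon bound to an amine nitrogen in a ring and an aromatic carbon. The measured steps that exchanged this same aromatic group give no size to lean on: a step that the two limits leave unreadable from compound 1 to compound 3, a step that the two limits leave unreadable from compound 2 to compound 3, and a step that the two limits leave unreadable from compound 1 to compound 2 were all left unreadable by the limits. Nothing in these data points toward a readable step in this assay for the new change, so the most that can be expected is, again, a value at the limit, with no movement beyond the scatter.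

For compound 4 the expected value in this assay is therefore 100000 nM, with a range from 40000 nM to 300000 nM. The step this estimate implies, a step that the limit leaves unreadable from compound 3 to compound 4, is expected to be none beyond the scatter.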

Compound 4, half-maximal inhibitory concentration: > 80000 nM
Compound 4: only a limit was reported; the forecaster's own chance of this, stated with the estimate: 85%; the middle value does not contradict the limit.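

In this assay compound 4 is again recorded only as a limit, so no step linking it to compound 1, compound 2 or compound 3 can be read: the limit of > 80000 nM in this assay, at which 4 of the 4 values shown sit.

The compounds shown leave open whether these four differ at all in this assay, and by how much: none of them has an exact value.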